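Bromine on the Pyridine Ring of an Azaindole Nicotinic Ligand

This account rests on a few compounds, and the source may have more. Where it says the series, first, only, none or still open, it means among the compounds named here.

Compound 1, `c1cnc2[nH]c(C[C@H]3CCCN3)cc2c1`, was tested in an assay on membranes from brain for displacement of a labelled ligand from Neuronal acetylcholine receptor; alpha4/beta2 (Rattus norvegicus) (on this read-out lower numbers stand for stronger inhibition and higher numbers for weaker inhibition), where compound 1 gives 125 nM. Within the data shown here, its only measured neighbour is compound 2, `CN1CCC[C@@H]1Cc1cc2cccnc2[nH]1`, which in this assay gives 2510 nM; the step from compound 1 to compound 2 is a 20-fold higher number from compound 1 to compound 2 (1.30 log units; beyond the scatter), arising from a methyl in place of hydrogen on an amine nitrogen in a ring. Compound 1 therefore stands at the lowest of the two numbers.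

Compound 3, `Brc1ccc2cc(C[C@H]3CCCN3)[nH]c2n1`, differs from compound 1 by bromo in place of hydrogen on an aromatic carbon, a bromo in place of hydrogen on an aromatic carbon, next to the ring nitrogen. Among the measured compounds shown here, no measured step touches this part of the molecule: the one known step concerns the pyrrolidine nitrogen, not the aromatic ring, so it offers no guide here. With the amine left untouched, compound 3 is expected to stay near compound 1, and the estimated step is a 2.1-fold lower number from compound 1 to compound 3 (0.32 log units; beyond the scatter). The estimate for compound 3 is 60 nM, within a range from 12 nM to 300 nM.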

Compound 3, inhibition constant: 691 nM
Compound 3: the middle estimate sits 12-fold (1.06 log units) below what was measured; measured number outside the range, above it.
By their numbers in this assay, from the lowest: compound 1; then compound 3; then compound 2.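

In this assay, bromo in place of hydrogen on an aromatic carbon gives a 5.5-fold higher number from compound 1 to compound 3 (0.74 log units; beyond the scatter), the opposite direction from a stronger result. The earlier step, a 20-fold higher number from compound 1 to compound 2 (1.30 log units; beyond the scatter), concerned only the amine nitrogen in the ring, whereas this one shows that the number also responds to a change on the six-membered aromatic ring, here at the carbon next to the ring nitrogen. No available measurement explains the rise at this position.

The compounds shown leave open whether this rise is particular to bromo or would also follow other groups on the same carbon, such as fluoro, chloro, methyl or a nitrile. They also leave open how bromo here would combine with methyl on the amine nitrogen in a single molecule.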